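Cytohesin-2 inhibition: working notes toward compound 3

The compounds below may be only part of what the source reports. "The series", "measured", "known", "first", "only" and "open" are said of these compounds alone.

Measured so far:
compound 1 `Cc1cc(O)cc(C)c1NS(=O)(=O)c1ccc([N+](=O)[O-])cc1` gives 540000 nM in an assay on isolated protein for inhibition of cytohesin-2 (Homo sapiens), read by fluorescence; a higher number here means a weaker inhibitor, a lower number a stronger inhibitor
compound 2 `Cc1ccc(S(=O)(=O)Nc2c(C)cc(O)cc2C)cc1` gives 1910000 nM in this assay

Compound 2 holds the highest of the two numbers in this assay; its nearest neighbour is compound 1, and the step of a 3.5-fold higher number from compound 1 to compound 2 (0.55 log units; beyond the scatter) lies beyond the scatter. Compound 3 `COc1ccc(S(=O)(=O)Nc2c(C)cc(O)cc2C)cc1` is the next to be measured. It differs from compound 2 by methoxy in place of methyl on an aromatic carbon. For the measured compounds named here, no measured pair in this set exchanges methyl for methoxy, so the only guide is the single step of a 3.5-fold higher number from compound 1 to compound 2 (0.55 log units; beyond the scatter), which shows how far one exchange on the same aromatic carbon moved the number. For compound 3 a change of similar or smaller size is expected, without a clear direction, so the estimated step of a 1.3-fold lower number from compound 2 to compound 3 (0.10 log units; within the scatter) stays near the scatter. Compound 3 is expected at 1500000 nM in this assay, within 600000 nM to 4000000 nM.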

Compound 3, inhibition constant: 1610000 nM
Compound 3: middle estimate off by 1.1-fold (0.03 log units), on the low side, within the range that was stated.
By their numbers in this assay, from the lowest: compound 1; then compounds 3 and 2 (each within the scatter of the next).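

At this aromatic carbon, para to a large group, methoxy in place of methyl gives a 1.2-fold lower number from compound 2 to compound 3 (0.07 log units; within the scatter) in this assay, so the added oxygen and hydrogen-bond acceptor do not separate the two compounds. Methoxy in place of nitro gives a 3.0-fold higher number from compound 1 to compound 3 (0.47 log units; beyond the scatter), which, with a 3.5-fold higher number from compound 1 to compound 2 (0.55 log units; beyond the scatter), places compound 1 apart from both others and makes it the strongest of the three inhibitors. No measurement on hand gives a reason for either step.

The compounds shown leave open whether the lower number of compound 1 is particular to nitro or would also appear with a carboxylic acid, a nitrile or an amine on this carbon. They also leave open whether a longer chain, such as ethoxy, would stay level with methoxy.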